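Ester chain variation in a cyclic urea series

The source may hold more compounds than are shown below. What is called first, only, known or untested is meant among the compounds shown, and "the series" means these compounds.

Measured compounds:
compound 1, `CC1=C(C(=O)OC(C)C)C(c2ccco2)NC(=O)N1C`, 18%
compound 2, `CCOC(=O)C1=C(C)N(C)C(=O)NC1c1cccs1`, 6%

In an assay on HeLa cells for displacement of a labelled ligand from adenosine receptor A3 (Homo sapiens), with a stated time of 180 min, tested at 10 uM (a higher number here means more inhibition at the concentration tested (going by the name of the read-out), a lower number less inhibition), compound 2 gives 6%, the lower of the two numbers recorded so far. The nearest number is that of compound 1, which in this assay gives 18%; the gap lies beyond the scatter. Compound 1 and compound 2 differ in more than one place, so no single step can be read between them.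

Compound 3, `CC1=C(C(=O)OC(C)C)C(c2cccs2)NC(=O)N1C`, is to be measured in this assay. It differs from compound 2 by methyl in place of hydrogen on a saturated chain carbon bound to an oxygen next to a carbonyl group and a saturated chain carbon.

Among the compounds with values here, no measured pair shows this change alone. Compound 1 carries the same isopropoxycarbonyl group, and its higher inhibition is the only hint available, so compound 3 is expected to move upward slightly, with an estimated step of a number 5 percentage points higher from compound 2 to compound 3 (within the scatter), a size that may well stay within the scatter. Compound 3 is expected to give 11%, with a likely range from 0% to 26%.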

Compound 3, a percentage reported as inhibition, at one concentration (the size of the read-out at that concentration, not a potency): 18%
Compound 3: the middle estimate sits 7 percentage points below what was measured; the range from low to high includes it.
By their numbers in this assay, from the lowest: compound 2; then compounds 1 and 3 (each within the scatter of the next).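

In this assay, ethoxycarbonyl to isopropoxycarbonyl now has a step of its own: the added methyl gives a number 12 percentage points higher from compound 2 to compound 3 (beyond the scatter) with thiophen-2-yl held fixed, although this rests on one pair. Within the data shown here, with isopropoxycarbonyl held fixed, thiophen-2-yl in place of furan-2-yl on a saturated ring carbon gives no change at the digits printed from compound 1 to compound 3 (within the scatter) for this pair, so of the two single changes read so far, only the one in the ester chain has a step beyond the scatter. Nothing on hand explains why the added methyl gives this step.

Going by these compounds, it remains open whether a butyl or benzyl ester, or a carboxylic acid, in place of isopropoxycarbonyl would continue this trend, and whether the methyl step also holds with furan-2-yl on the ring carbon. On these data alone, with compound 3 at 18% in this assay, a single-concentration percentage gives no potency, so the size of any effect on affinity for the receptor also stays open.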